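Swapping nitro for phenyl on compound 2

The source may report more compounds than this note shows. Statements on the series, on what has been measured and on what is new or still open speak of the compounds shown alone.

Compound 1 `Clc1ccc(NCc2cncn2Cc2ccc(-c3ccccc3)cc2)cc1-c1ccccc1` and compound 2 `COC(=O)c1ccc(NCc2cncn2Cc2ccc([N+](=O)[O-])cc2)cc1-c1ccccc1` have both been measured in a toxicity assay on NIH3T3 cells (Mus musculus) for cytotoxicity, read by resazurin assay; a higher number here means that more compound is needed for the effect, a lower number that less compound is needed. Compound 2 gives > 10000 nM, which is a limit of the assay and not a number. Compound 1 gives > 1000 nM, and this too is a limit. Neither compound therefore has an exact value to build on. Compound 3 `COC(=O)c1ccc(NCc2cncn2Cc2ccc(-c3ccccc3)cc2)cc1-c1ccccc1` has phenyl in place of nitro on an aromatic carbon, so 4-nitrophenyl becomes 4-phenylphenyl. Compound 1 also carries 4-phenylphenyl, and its limit is > 1000 nM. Among the measured compounds shown here, no measured step shows what this change does, so only a modest shift in this assay is expected, towards less compound being needed, with an estimated size of an at least 1.2-fold lower number from compound 2 to compound 3 (0.09 log units; that floor lies within the scatter). Compound 3 is expected at about 8000 nM, with an estimated range of 2000 nM to 20000 nM.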

Compound 3, half-maximal effective concentration: > 1000 nM
Compound 3: a limit, no number (the forecaster's own chance of this, stated with the estimate: 60%); the middle value lies beyond the limit too.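

Among the compounds shown here, compound 1, compound 2 and compound 3 all stand at limits of this assay, so no step between them can be read. Still open, on these data alone, is how much of each compound the effect needs, and whether phenyl in place of nitro or methoxycarbonyl in place of chloro changes that amount.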